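This account rests on a few compounds, and the source may have more. Where it says the series, first, only, none or still open, it means among the compounds named here.

Measured so far:
compound 1 `Cc1ccc(C)c(OCc2nnc(C(=O)Nc3ccc(CCC(=O)O)cc3)s2)c1` — 1530 nM
compound 2 `Cc1ccc(OCc2nnc(C(=O)Nc3ccc(CCC(=O)O)cc3)s2)cc1C` — 1130 nM

In a functional assay on CHO cells for agonist activity at Free fatty acid receptor 1 (Homo sapiens), read by FLIPR and calcium flux, tested at 1 uM (on this read-out lower numbers stand for an effect already at smaller amounts and higher numbers for an effect only at larger amounts of compound), compound 2 gives 1130 nM, the lowest of the two numbers; the nearest is compound 1 with 1530 nM, and the step of a 1.4-fold lower number from compound 1 to compound 2 (0.13 log units; within the scatter) stays within the scatter, so the two cannot be ordered.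

Compound 3 `Cc1ccc(OCc2nnc(C(=O)Nc3ccc(CCC(=O)O)cc3)s2)c(C)c1` is not yet measured. Against compound 2 it shows (2,4-dimethylphenyl in place of 3,4-dimethylphenyl on an oxygen on a saturated carbon); the two have the same atoms, joined differently. Within the data shown here, the only step that bears on this kind of change is the one from compound 1 to compound 2, a 1.4-fold lower number from compound 1 to compound 2 (0.13 log units; within the scatter), which also moved methyl groups around the same ring and did not leave the scatter. On that basis a further rearrangement of the two methyls is expected to change little in this assay, with no direction beyond the scatter.

The step from compound 2 to compound 3 is estimated at a 1.1-fold higher number from compound 2 to compound 3 (0.03 log units; within the scatter). Compound 3 is therefore expected to give about 1200 nM in this assay, within 550 nM to 2600 nM.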

Compound 3, half-maximal effective concentration: 2540 nM
The estimate for compound 3 lay 2.1-fold (0.33 log units) below the measured number, within the range that was stated.
By their numbers in this assay, from the lowest: compounds 2, 1 and 3 (each within the scatter of the next, the first and the last beyond it).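

In this assay, rearranging the two methyl groups on the phenyl ring now gives a step that leaves the scatter, a 2.2-fold higher number from compound 2 to compound 3 (0.35 log units; beyond the scatter), although the atoms stay the same and the change is modest. The other new step, a 1.7-fold higher number from compound 1 to compound 3 (0.22 log units; within the scatter), stays within the scatter, so 2,4-dimethylphenyl and 2,5-dimethylphenyl cannot be ordered here, and among the three compounds only 3,4-dimethylphenyl and 2,4-dimethylphenyl are separated. No measurement at hand accounts for this difference.

Going by these compounds, it remains open whether a methoxy group or a chlorine in place of either methyl, or a phenyl ring with no methyl groups, would move the number beyond the scatter. On these data alone, it also remains open whether the gap between 3,4-dimethylphenyl and 2,4-dimethylphenyl would persist with a shorter chain to the carboxylic acid.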